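Ring Amine in Place of Dimethylamino on the Side Chain

This account rests on a few compounds, and the source may have more. Where it says the series, first, only, none or still open, it means among the compounds named here.

Of the compounds shown here, three of one series have been measured in a functional assay on MCF7 cells (Homo sapiens) for cytotoxicity, read by MTT assay, with a stated time of 72 h; a higher number here means a weaker inhibitor, a lower number a stronger inhibitor. Compound 1 `COc1ccccc1-c1cc(=O)c2c(O)cc(OCCCCN3CCN(C)CC3)c(OC)c2o1` gives 5430 nM, compound 2 `COc1c(OCCCCN2CCN(C)CC2)cc(O)c2c(=O)cc(-c3ccc(F)cc3Br)oc12` gives 3090 nM, and compound 3 `CN(C)CCCOc1c(OCc2ccccc2)cc(O)c2c(=O)cc(-c3ccccc3)oc12` gives 3210 nM. Going by the values given here, the one step between neighbours, a 1.8-fold lower number from compound 1 to compound 2 (0.24 log units; within the scatter), concerns the aryl group only. All three numbers lie within the scatter of one another; the value of compound 3 is nearest to that of compound 2 and furthest from that of compound 1, and neither gap exceeds the scatter.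

Compound 4 `O=c1cc(-c2ccccc2)oc2c(OCCCN3CCCC3)c(OCc3ccccc3)cc(O)c12` differs from compound 3 in a single place: pyrrolidin-1-yl in place of dimethylamino on a saturated chain carbon, three bonds along the chain from an oxygen on an aromatic ring. Among the compounds with values here, none of the measured steps touches this part of the molecule, so nothing among the measured compounds bears directly on it. Within the data shown here, with no precedent for the change, the step expected, a 1.0-fold lower number from compound 3 to compound 4 (0.00 log units; within the scatter), is estimated to be none beyond the scatter. Compound 4 is therefore expected to give about 3200 nM in this assay, with a range from 1400 nM to 7500 nM.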

Compound 4, half-maximal inhibitory concentration: 2230 nM
Compound 4: middle estimate off by 1.4-fold (0.16 log units), on the high side; low and high end bracket the measured number.
By their numbers in this assay, from the lowest: compounds 4, 2, 3 and 1 (each within the scatter of the next, the first and the last beyond it).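

Going by these compounds alone, the exchange of dimethylamino for pyrrolidin-1-yl is the only step here that touches the amine of the side chain, and in this assay it amounts to a 1.4-fold lower number from compound 3 to compound 4 (0.16 log units; within the scatter). On the core of compound 3, then, this position accepts the five-membered ring amine in place of the open dimethylamino group, with no difference that can be told from the scatter. No measurement at hand explains this result or shows why the two amines read alike.

The compounds shown leave open whether a piperidine, a morpholine or a primary amine would read the same at the end of this chain, and whether a longer chain would alter the outcome. They also leave open whether the same exchange would give a similar step on a core with a different aryl group, such as that of compound 2.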